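This account rests on a few compounds, and the source may have more. Where it says the series, first, only, none or still open, it means among the compounds named here.

Of the compounds shown here, three that share one core have been tested in a functional assay on HCT-116 cells (Homo sapiens) for inhibition, read by sulforhodamine B assay, with a stated time of 72 h; on this read-out higher numbers stand for weaker inhibition and lower numbers for stronger inhibition. Compound 1 `COc1ccc2cc(C(C)c3nnc4n3N=C(c3ccc(Cl)cc3Cl)CS4)ccc2c1` gives 14000 nM. Compound 2 `CC(C)Cc1ccc(C(C)c2nnc3n2N=C(c2ccc(OC(F)(F)F)cc2)CS3)cc1` gives 3000 nM, and compound 3 `CC(c1ccc(-c2ccccc2)c(F)c1)c1nnc2n1N=C(c1ccc(Br)cc1)CS2` gives 7100 nM. Compound 2 thus shows the lowest of the three numbers, with compound 3 sitting beyond the scatter above it and compound 1 further still.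

Compound 4 `Cc1ccc(C2=Nn3c(nnc3C(C)c3ccc(CC(C)C)cc3)SC2)cc1` has not yet been measured. It differs from compound 2 at one place: methyl in place of trifluoromethoxy on an aromatic carbon. Among the compounds with values here, no pair among the measured compounds differs in a single place, so no measured step shows what such a swap does on this core. In this assay a modest step from compound 2 to compound 4 is expected, most likely toward a somewhat higher number, though a change that stays within the scatter would not be surprising. The expected step is a 1.7-fold higher number from compound 2 to compound 4 (0.22 log units; within the scatter). Compound 4 is expected to give 5000 nM, within a range from 1500 nM to 15000 nM.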

Compound 4, half-maximal inhibitory concentration: 4000 nM
Compound 4: the middle estimate sits 1.3-fold (0.10 log units) above what was measured; the range from low to high includes it.
By their numbers in this assay, from the lowest: compounds 2, 4, 3 and 1 (each within the scatter of the next, the first and the last beyond it).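

In this assay, within the data shown here, the first single-place swap on this core gives a 1.3-fold higher number from compound 2 to compound 4 (0.12 log units; within the scatter), so the two compounds cannot be told apart on this read-out. At this position on the six-membered aromatic ring, para to a large group, trifluoromethoxy with its 5 heavy atoms can therefore give way to methyl with its 1 heavy atom without a change that stands clear of repeat scatter. No measurement at hand speaks to why these two groups read alike.

As far as these compounds go, what an amine or a carboxylic acid at this position would do remains open, since both groups compared here carry no charge and no hydrogen-bond donor. Also open, from the compounds shown here alone, is whether the same swap would read alike on a compound with a different group at the other end of the shared core.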